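A few compounds are considered here, and "the series" means these few. Any claim that something is new, unique, unknown or untested is made for them only; others in the source may bear on it.

Measured so far in a functional assay on NCI-H460 cells (Homo sapiens) for cytotoxicity, read by sulforhodamine B assay, with a stated time of 48 h; on this read-out higher numbers stand for weaker inhibition of growth and lower numbers for stronger inhibition of growth:
compound 1 `ClCc1ccc(Cn2cnc3c(Cl)ncnc32)cc1` — 1820 nM
compound 2 `ClCc1ccc(Cn2cnc3nc(Cl)nc(Cl)c32)cc1` — 35500 nM
compound 3 `ClCc1cccc(Cn2cnc3c(Cl)nc(Cl)nc32)c1` — 6310 nM

Compound 1 gives the lowest number of the three, and both other compounds lie beyond the scatter from it: compound 3 shows a markedly higher number, and compound 2 a much higher one still. Compound 4 `ClCc1ccc(Cn2cnc3c(Cl)nc(Cl)nc32)cc1` has not been measured. It differs from compound 1 by chloro in place of hydrogen on an aromatic carbon. Among the measured compounds shown here, the two measured compounds that carry a second chloro on the core both give higher numbers than compound 1, so the added chloro is expected to raise the number, though no one-place step fixes its size. The expected step from compound 1 to compound 4 is a 2.7-fold higher number from compound 1 to compound 4 (0.44 log units; beyond the scatter). Compound 4 is estimated at 5000 nM, with a range from 1800 nM to 14000 nM.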

Compound 4, concentration for total growth inhibition: 4900 nM
For compound 4 the middle estimate is 1.0-fold (0.01 log units) above the measured one; low and high end bracket the measured number.
By their numbers in this assay, from the lowest: compound 1; then compounds 4 and 3 (each within the scatter of the next); then compound 2.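

In this assay, among the compounds shown here, chloro in place of hydrogen on the aromatic carbon between two ring nitrogen atoms gives a 2.7-fold higher number from compound 1 to compound 4 (0.43 log units; beyond the scatter), the first one-place step. The position therefore accepts chloro at a modest cost in growth inhibition, with compound 4 still at 4900 nM. Nothing available explains this step.

From the compounds shown here alone, whether an amine or a methoxy group at this position would shift the number as chloro does remains open. Going by these compounds, it is also open whether the step would keep its size with other groups in place of the chloromethyl group.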